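Trimming the Side Chain Down to a Carbamoyl Group

The compounds below may be only part of what the source reports. "The series", "measured", "known", "first", "only" and "open" are said of these compounds alone.

Compound 1: `CCNC(=O)c1noc(-c2cc(C(C)C)c(O)cc2O)c1-c1cc(COCC(N)=O)no1` — 97 nM
Compound 2: `CCNC(=O)c1noc(-c2cc(C(C)C)c(O)cc2O)c1-c1cc(CNC(C)=O)no1` — 167 nM
Compound 3: `CCNC(=O)c1noc(-c2cc(C(C)C)c(O)cc2O)c1-c1cc(CNCCO)no1` — 111 nM

In a functional assay on HCT-116 cells (Homo sapiens) for inhibition (a higher number here means a weaker inhibitor, a lower number a stronger inhibitor), compound 3 gives 111 nM, the second highest of the three numbers, and the steps to both neighbours, a 1.1-fold higher number from compound 1 to compound 3 (0.06 log units; within the scatter) and a 1.5-fold lower number from compound 2 to compound 3 (0.18 log units; within the scatter), stay within the scatter. The three measured compounds share one core and differ only in the group carried on the saturated chain carbon bound to the aromatic carbon.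

Compound 4, `CCNC(=O)c1noc(-c2cc(C(C)C)c(O)cc2O)c1-c1cc(C(N)=O)no1`, goes further: carbamoyl in place of ((2-hydroxyethyl)amino)methyl on an aromatic carbon. Here the chain carbon itself disappears and the carbamoyl sits directly on the ring.

Within the data shown here, no measured step removes that carbon, so none matches the change exactly. What the measured steps do show is that the group at this place has been swapped three ways — a 1.7-fold higher number from compound 1 to compound 2 (0.24 log units; within the scatter), a 1.1-fold higher number from compound 1 to compound 3 (0.06 log units; within the scatter) and a 1.5-fold lower number from compound 2 to compound 3 (0.18 log units; within the scatter) — without any step leaving the scatter. On that basis compound 4 is expected to behave like the others, with an estimated step of a 1.2-fold higher number from compound 3 to compound 4 (0.07 log units; within the scatter), that is, nothing beyond the scatter in either direction. The estimate for compound 4 in this assay is 130 nM, with a range from 50 nM to 350 nM.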

Compound 4, half-maximal inhibitory concentration: 79 nM
Compound 4: middle estimate off by 1.6-fold (0.22 log units), on the high side, and the stated range covers the measured number.
By their numbers in this assay, from the lowest: compounds 4, 1, 3 and 2 (each within the scatter of the next, the first and the last beyond it).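

Compound 4 shows that this position does not depend on the saturated chain carbon: with carbamoyl directly on the aromatic carbon in this assay, both a 1.4-fold lower number from compound 3 to compound 4 (0.15 log units; within the scatter) and a 1.2-fold lower number from compound 1 to compound 4 (0.09 log units; within the scatter) remain small. Among these compounds, the change also yields the only modest step to leave the scatter, a 2.1-fold lower number from compound 2 to compound 4 (0.33 log units; beyond the scatter), where carbamoyl replaces acetamidomethyl, so the groups at this position can be told apart, though only for this one pair. Nothing shown here accounts for that separation from compound 2 or for the closeness to compound 1 and compound 3.

The compounds shown leave open whether a carboxylic acid, a nitrile or an N-methylcarbamoyl group on the same aromatic carbon would stay in this range of numbers. They also leave open whether an amine or a hydroxymethyl group placed there would separate from compound 4 in the same way as acetamidomethyl, or whether that gap is particular to the pair already compared.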